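This account rests on a few compounds, and the source may have more. Where it says the series, first, only, none or still open, it means among the compounds named here.

Of the compounds shown here, three sharing one core have been tested in a physicochemical assay for metabolic stability, read by LC-MS, in phosphate buffer, with a stated time of 3 h, at pH 7.4, tested at 50 uM; a higher number here means that more of the compound is left, a lower number that less of the compound is left. Compound 1 `CC(C)C(=O)OCOC(=O)C1=C(S[C@@H]2CN[C@H](C(=O)Nc3cccc(C(=O)O)c3)C2)[C@H](C)[C@@H]2[C@@H]([C@@H](C)O)C(=O)N12` gives > 95%, which is a limit rather than a number. Compound 3 `CCOC(=O)C1=C(S[C@@H]2CN[C@H](C(=O)Nc3cccc(C(=O)OCC)c3)C2)[C@H](C)[C@@H]2[C@@H]([C@@H](C)OC(=O)CC)C(=O)N12` likewise gives > 95%, again a limit. Compound 2 `CC(C)OC(=O)c1cccc(NC(=O)[C@@H]2C[C@H](SC3=C(C(=O)O)N4C(=O)[C@H]([C@@H](C)O)[C@H]4[C@H]3C)CN2)c1` gives > 95%, also a limit and not a number, so it stands together with the other two at the limit of > 95% in this assay, at which 3 of the 3 values shown sit. Compound 4 `C[C@@H](O)[C@H]1C(=O)N2C(C(=O)O)=C(S[C@@H]3CN[C@H](C(=O)Nc4cccc(C(=O)OCC(F)(F)F)c4)C3)[C@H](C)[C@H]12` is not yet measured; it differs from compound 2 by 2,2,2-trifluoroethyl in place of isopropyl on an oxygen next to a carbonyl group. With every value shown sitting at the same limit, no step beyond the scatter is expected in this assay. The expected step is a step that the limit leaves unreadable from compound 2 to compound 4. Compound 4 is therefore estimated at 97%, with a range from 90% to 100%.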

Compound 4, percent of the compound remaining: > 95%
Compound 4 gave a limit, no number; the forecaster's own chance of this, stated with the estimate: 85%; the middle value does not contradict the limit.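

For the compounds shown here, compound 2 and compound 4 both give only a limit, and no step between them can be read. The compounds shown leave open whether 2,2,2-trifluoroethyl in place of isopropyl changes the percent of compound remaining at all.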